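The source may report more compounds than this note shows. Statements on the series, on what has been measured and on what is new or still open speak of the compounds shown alone.

Compound 1 `Cc1cccc(OC(c2ccc(Br)cc2)C2CCN(C(C)CCNC(=O)c3c(Cl)cncc3Cl)CC2)n1` is tested in an ADME assay on PBMC cells (Homo sapiens) for cytotoxicity (on this read-out lower numbers stand for higher toxicity in this test and higher numbers for lower toxicity in this test), where compound 1 gives 6500 nM. Its closest neighbour is compound 2 `Cc1cccc(OC(c2ccc(C(F)(F)F)cc2)C2CCN(C(C)CCNC(=O)c3c(Cl)cncc3Cl)CC2)n1`, which in this assay gives 6700 nM; the two numbers sit within the scatter of each other, as the change a 1.0-fold higher number from compound 1 to compound 2 (0.01 log units; within the scatter) shows.

Compound 3 `CC(CCNC(=O)c1c(Cl)cncc1Cl)N1CCC(C(Oc2ccccn2)c2ccc(Br)cc2)CC1` has not yet been measured in this assay. It differs from compound 1 in one place: hydrogen in place of methyl on an aromatic carbon. Going by the values given here, no measured step touches this part of the molecule; the only step known, from bromo to trifluoromethyl on a different ring, left the number unchanged. There is therefore no basis for expecting a shift, and the estimate for compound 3 is that it stays near compound 1, with the step of no change at the digits printed from compound 1 to compound 3 (within the scatter) expected to lie within the scatter. Compound 3 is estimated at 6500 nM, with a likely range from 3000 nM to 14000 nM.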

Compound 3, half-maximal cytotoxic concentration: 33700 nM
The estimate for compound 3 lay 5.2-fold (0.71 log units) below the measured number, outside the stated range (above it).
By their numbers in this assay, from the lowest: compounds 1 and 2 (each within the scatter of the next); then compound 3.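

The change from 6-methylpyridin-2-yl to pyridin-2-yl is the first shown at this position, and in this assay it gives a 5.2-fold higher number from compound 1 to compound 3 (0.71 log units; beyond the scatter), which means lower toxicity in this test once the methyl is gone. A single carbon next to the ring nitrogen therefore matters on this read-out, whereas the swap of bromo for trifluoromethyl on the other ring stayed within the scatter, with a 1.0-fold higher number from compound 1 to compound 2 (0.01 log units; within the scatter). Nothing available gives a reason for this rise.

As far as these compounds go, what an ethyl, a methoxy or a chlorine in that same place would give remains open, so one hydrogen and one methyl cannot show a trend. From the compounds shown here alone, it is also open whether removing the methyl from compound 2, which carries trifluoromethyl instead of bromo, would give a step of similar size.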